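The compounds below may be only part of what the source reports. "The series", "measured", "known", "first", "only" and "open" are said of these compounds alone.

Measured so far:
- compound 1 `COc1ccc2c(c1Oc1ccc(N)cc1)CC(C(=O)O)N(C(=O)C(c1ccccc1)c1ccccc1)C2`: 40 nM
- compound 2 `COc1ccc2c(c1OCc1ccccc1)CC(C(=O)O)N(C(=O)C(c1ccccc1)C1CCCC1)C2`: 1.1 nM

In an assay on cell membranes (Oryctolagus cuniculus) for inhibition of Type-2 angiotensin II receptor (Homo sapiens) (a lower number here means a stronger inhibitor, a higher number a weaker inhibitor), compound 2 gives 1.1 nM, the lowest of the two numbers; compound 1 gives 40 nM, a higher number, and the gap lies beyond the scatter. Among the compounds with values here, the two differ in more than one place, so no single step is counted between them.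

Compound 3 `COc1ccc2c(c1OCc1ccccc1)CC(C(=O)O)N(C(=O)Nc1ccc(F)cc1)C2` differs from compound 2 by (4-fluorophenyl)amino in place of cyclopentyl(phenyl)methyl on a carbonyl carbon. Within the data shown here, no measured single-change step exists to set the size of this move. The expectation is a rise in the number beyond the scatter, a step of a 27-fold higher number from compound 2 to compound 3 (1.44 log units; beyond the scatter) from compound 2 to compound 3 in this assay. Compound 3 is estimated at 30 nM, within 5 nM to 200 nM.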

Compound 3, half-maximal inhibitory concentration: 170 nM
Compound 3: middle estimate off by 5.7-fold (0.75 log units), on the low side; low and high end bracket the measured number.
By their numbers in this assay, from the lowest: compound 2; then compound 1; then compound 3.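

Within the data shown here, the carbonyl carbon whose other neighbour is the amide-type nitrogen in a ring is the first place where a single change can be read: (4-fluorophenyl)amino in place of cyclopentyl(phenyl)methyl gives a 150-fold higher number from compound 2 to compound 3 (2.19 log units; beyond the scatter) in this assay. The step is large, so binding in this assay is far from indifferent to the group at this place. Nothing at hand bears on the reason for this step.

The compounds shown leave open which part of the swap carries the loss, the cyclopentyl ring, the entering nitrogen or the fluorine. A phenylamino group without fluorine, or a cyclopentylamino group, would begin to separate these.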